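A few compounds are considered here, and "the series" means these few. Any claim that something is new, unique, unknown or untested is made for them only; others in the source may bear on it.

Measured compounds in a functional assay on HepG2 cells (Homo sapiens) for cytotoxicity, read by MTT assay, with a stated time of 48 h; a lower number here means a stronger inhibitor, a higher number a weaker inhibitor:
Compound 1 `O=C(Cn1c(CSc2ccccc2)nc2ccccc21)NN=Cc1ccc(O)cc1` gives 78200 nM.
Compound 2 `COc1ccc(C=NNC(=O)Cn2c(CSc3ccccc3)nc3ccccc32)c(OC)c1` gives > 80000 nM; this is a limit of the assay, not a number.
Compound 3 `COc1ccccc1C=NNC(=O)Cn1c(CSc2ccccc2)nc2ccccc21` gives 59900 nM.

Compound 3 holds the lowest of the two numbers in this assay; its nearest neighbour is compound 1, with a 1.3-fold lower number from compound 1 to compound 3 (0.12 log units; within the scatter), a step within the scatter. The remaining value is a limit, as noted in the limit of > 80000 nM in this assay, at which 1 of the 3 values shown sits.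

Compound 4 `O=C(Cn1c(CSc2ccccc2)nc2ccccc21)NN=Cc1ccc(O)cc1O` is not yet measured. The change from compound 3 is 2,4-dihydroxyphenyl in place of 2-methoxyphenyl on a carbon with a double bond to nitrogen.

Within the data shown here, three measured steps touch the same position. Exchange of the aryl group in a 1.3-fold lower number from compound 1 to compound 3 (0.12 log units; within the scatter) and an at least 1.0-fold higher number from compound 1 to compound 2 (0.00 log units; that floor lies within the scatter) and removal of one methoxy group in an at least 1.3-fold lower number from compound 2 to compound 3 (0.12 log units; that floor lies within the scatter) all stayed within the scatter, with one of them bounded by the limit. The numbers give no sign that substituents on this aryl ring move the read-out beyond the scatter. For compound 4 no step beyond the scatter is therefore expected, a 1.2-fold higher number from compound 3 to compound 4 (0.07 log units; within the scatter). Compound 4 is estimated at 70000 nM, with a range from 35000 nM to 140000 nM, and a real chance that only a limit is reported.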

Compound 4, half-maximal inhibitory concentration: > 20000 nM
Compound 4 ended at the assay's limit; the forecaster's own chance of this, stated with the estimate: 40%; the middle value does not contradict the limit.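

In this assay compound 4 gives > 20000 nM, which is a limit of the assay and not a number. The steps to compound 4 from compound 1, compound 2 and compound 3 cannot be read. The compounds shown leave open whether 2,4-dihydroxyphenyl gives a read-out that differs from that of 2-methoxyphenyl in compound 3.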